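Replacing the bromine-bearing arm of compound 1

The compounds below may be only part of what the source reports. "The series", "measured", "known", "first", "only" and "open" are said of these compounds alone.

Measured so far:
compound 1 `CCOC(=O)C1=C(N/N=C(/Br)c2ccccc2)Nc2[nH]nc(C)c2C1c1ccc(N(C)C)cc1` gives 72000 nM;
compound 2 `CCOC(=O)C1=C(N/C=N/c2ncc(-c3ccccc3)s2)Nc2[nH]nc(C)c2C1c1ccc(N(C)C)cc1` gives 9790 nM;
compound 3 `CCOC(=O)C1=C(N/C=N/c2ccccn2)Nc2[nH]nc(C)c2C1c1ccc(N(C)C)cc1` gives 26200 nM.

In a functional assay on HepG2 cells (Homo sapiens) for inhibition, read by MTT assay, with a stated time of 48 h (on this read-out lower numbers stand for stronger inhibition and higher numbers for weaker inhibition), compound 1 stands with the highest number of the three measured compounds. Its nearest neighbour is compound 3, and the step of a 2.7-fold lower number from compound 1 to compound 3 (0.44 log units; beyond the scatter) is modest; compound 2 lies further off with a number lower than that of compound 1.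

Compound 4 `CCOC(=O)C1=C(N/C=N/c2ccc(C)cc2)Nc2[nH]nc(C)c2C1c1ccc(N(C)C)cc1` is not yet measured. It differs from compound 1 in one place: a group of 9 heavy atoms (8 carbon, 1 nitrogen; one six-membered aromatic ring of carbon only) in place of a group of 9 heavy atoms (7 carbon, 1 nitrogen, 1 bromine; one six-membered aromatic ring of carbon only), on an amine nitrogen. The step that bears most directly on this change is a 2.7-fold lower number from compound 1 to compound 3 (0.44 log units; beyond the scatter), where the same bromine-bearing group was exchanged for a six-membered aromatic ring with one nitrogen on the amine nitrogen. The step of a 2.7-fold higher number from compound 2 to compound 3 (0.43 log units; beyond the scatter) shows that swapping one aromatic ring for another on the double-bonded nitrogen moves the number by a similar, modest amount. Compound 4 is therefore expected to sit modestly below compound 1, with an expected step of a 2.9-fold lower number from compound 1 to compound 4 (0.46 log units; beyond the scatter). The estimate for compound 4 is 25000 nM, in a range from 8000 nM to 70000 nM.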

Compound 4, half-maximal inhibitory concentration: 44400 nM
Estimate against measurement, compound 4: 1.8-fold (0.25 log units) below; the measured number falls inside the stated range.
By their numbers in this assay, from the lowest: compound 2; then compounds 3, 4 and 1 (each within the scatter of the next, the first and the last beyond it).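

In this assay, exchanging the bromine-bearing group on the amine nitrogen for the group carrying 4-methylphenyl gives a 1.6-fold lower number from compound 1 to compound 4 (0.21 log units; within the scatter), so unlike the exchange that led to compound 3, this change does not separate its two compounds beyond the scatter. On the double-bonded nitrogen, 4-methylphenyl and pyridin-2-yl are not told apart, with a 1.7-fold higher number from compound 3 to compound 4 (0.23 log units; within the scatter). By contrast, 5-phenyl-1,3-thiazol-2-yl stands clearly apart from 4-methylphenyl, with a 4.5-fold higher number from compound 2 to compound 4 (0.66 log units; beyond the scatter), so compound 2 now stands beyond the scatter from each of the other three compounds.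

The compounds shown leave open whether an amine or a carboxylic acid on the phenyl ring of compound 4 would move the number in this assay. Nothing shown gives a reason for any of these differences.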